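A few compounds are considered here, and "the series" means these few. Any claim that something is new, unique, unknown or untested is made for them only; others in the source may bear on it.

Measured so far in a functional assay on SW-620 cells (Homo sapiens) for inhibition, read by MTT assay, with a stated time of 72 h; on this read-out lower numbers stand for stronger inhibition of growth and higher numbers for weaker inhibition of growth:
Compound 1 `Cc1cc(CN2CCN(c3c(Br)cnc4[nH]c(-c5nc(C)oc5C)nc34)CC2)no1`: 4570 nM
Compound 2 `Cc1cc(CN2CCN(c3c(Cl)cnc4[nH]c(-c5cnn(C)c5)nc34)CC2)no1`: 1800 nM

Of these two, compound 1 has the higher number and is therefore the weaker inhibitor of growth. Compound 2 lies lower by more than the usual scatter. For the measured compounds named here, the two compounds differ in more than one place, so no single-change step is available as a guide.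

Compound 3 `Cc1cc(CN2CCN(c3c(Br)cnc4[nH]c(-c5csnn5)nc34)CC2)no1` has not yet been measured. It departs from compound 1 in one place: 1,2,3-thiadiazol-4-yl in place of 2,5-dimethyl-1,3-oxazol-4-yl on an aromatic carbon. In words, 1,2,3-thiadiazol-4-yl stands in place of 2,5-dimethyl-1,3-oxazol-4-yl on an aromatic carbon.

The expectation rests on thin evidence. Going by the values given here, the only other measured compound, compound 2 at 1800 nM, also lacks the 2,5-dimethyl-1,3-oxazol-4-yl group and has the lower number. A small step toward a lower number is expected in this assay, estimated as a 1.6-fold lower number from compound 1 to compound 3 (0.21 log units; within the scatter), and it may not clear the scatter. For compound 3 the estimated value is 2800 nM, with an expected range of 1000 nM to 7500 nM.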

Compound 3, concentration for 50% growth inhibition: 20000 nM
The estimate for compound 3 lay 7.1-fold (0.85 log units) below the measured number; the whole stated range lies below it.
By their numbers in this assay, from the lowest: compound 2; then compound 1; then compound 3.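

In this assay, for the compounds shown here, the change at this position, an aromatic carbon of a five-membered aromatic ring with 2 nitrogen, gives a 4.4-fold higher number from compound 1 to compound 3 (0.64 log units; beyond the scatter) and thus shows, as the earlier compounds could not, that the group held here alone can shift growth inhibition beyond the scatter. Here 1,2,3-thiadiazol-4-yl does worse than 2,5-dimethyl-1,3-oxazol-4-yl, although the change alters several things at once: the entering ring has fewer heavy atoms, carries sulfur and no oxygen, and has 3 ring hetero atoms in place of 2. No measurement shown ties the step to any one of these differences.

As far as these compounds go, it remains open whether the higher number belongs to the thiadiazole ring itself or to the absence of the two methyl groups, and whether a plain phenyl group or a small amine at this position would move the number in either direction. Also open, from the compounds shown here alone, is whether the step would hold with chlorine in place of bromine, since compound 2 differs from compound 3 in more than one place and cannot settle this.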